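This account rests on a few compounds, and the source may have more. Where it says the series, first, only, none or still open, it means among the compounds named here.

In a functional assay on cells for agonist activity at C-X-C chemokine receptor type 4 (Homo sapiens), read by fluorescence and calcium flux, with a stated time of 90 s (on this read-out higher numbers stand for an effect only at larger amounts of compound and lower numbers for an effect already at smaller amounts), compound 1 `c1ccc2c(c1)CN[C@@H](CN(CCCCNCC1CCOCC1)[C@H]1CCCc3cccnc31)C2` gives > 30000 nM, which is a limit of the assay and not a number. Compound 2 `O=S1(=O)CCC(NCCCCN(C[C@H]2Cc3ccccc3CN2)[C@H]2CCCc3cccnc32)CC1` likewise gives > 30000 nM, also a limit. The step that the two limits leave unreadable from compound 1 to compound 2 therefore cannot be read. Compound 3 `CC(C)(CCN(C[C@H]1Cc2ccccc2CN1)[C@H]1CCCc2cccnc21)CNC1CCC(F)(F)CC1` gives > 30000 nM, again a limit, so compound 3 stands at the limit of > 30000 nM in this assay, at which 3 of the 3 values shown sit, together with the other two. Compound 4 `CC(C)(CCN(C[C@H]1Cc2ccccc2CN1)[C@H]1CCCc2cccnc21)CNC1CCOCC1` differs from compound 3 by oxan-4-yl in place of 4,4-difluorocyclohexyl on an amine nitrogen. For the measured compounds named here, no measured step bears on this change, since the only recorded step is unreadable. Because compound 3 rests on (the limit of > 30000 nM in this assay, at which 3 of the 3 values shown sit), compound 4 is expected to remain there as well, and the step of a number no higher from compound 3 to compound 4 (the limit leaves the size open) is expected to show no effect beyond the scatter. Compound 4 is accordingly estimated at 30000 nM, between 10000 nM and 100000 nM.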

Compound 4, half-maximal effective concentration: > 30000 nM
Compound 4 ended at the assay's limit; the forecaster's own chance of this, stated with the estimate: 85%; the middle value lies on the limit itself.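

Compound 4 rests at a limit, not a number, so none of its steps from compound 1, compound 2 or compound 3 can be read: the limit of > 30000 nM in this assay, at which 4 of the 4 values shown sit.

The compounds shown leave open which structural change, if any, would give a numerical reading in this assay.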